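Cytotoxicity notes: isobutoxy to benzyloxy in a biaryl amide pair

The source may hold more compounds than are shown below. What is called first, only, known or untested is meant among the compounds shown, and "the series" means these compounds.

Measured so far:
Compound 1, `CC(C)N(Cc1cccc(OCCCCCC(=O)O)c1)C(=O)c1ccc(-c2cccc(OCc3ccccc3)c2)cc1`; in an ADME assay on Raji cells (Homo sapiens) for cytotoxicity, read by CellTiter-Glo and resazurin assay, with a stated time of 72 h (a lower number here means that less compound is needed, a higher number that more compound is needed for the effect), compound 1 gives > 26000 nM, which is a limit of the assay and not a number.
Compound 2, `CCOC(=O)CCCCCOc1cccc(CN(C(=O)c2ccc(-c3cccc(OCC(C)C)c3)cc2)C(C)C)c1`; in this assay compound 2 gives > 26000 nM, again a limit of the assay.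

Among the compounds with values here, compound 2 therefore stands nowhere on a numerical scale: only a limit is known for it, and the one further value shown, for compound 1, is a limit as well (the limit of > 26000 nM in this assay, at which 2 of the 2 values shown sit). Within the data shown here, compound 1 and compound 2 differ in more than one place, so no step between them is recorded; their two values show only that both reach the same limit.

Compound 3, `CCOC(=O)CCCCCOc1cccc(CN(C(=O)c2ccc(-c3cccc(OCc4ccccc4)c3)cc2)C(C)C)c1`, is not yet measured in this assay. Compared with compound 2 it carries phenyl in place of isopropyl on a saturated chain carbon bound to an oxygen on an aromatic ring; read one bond further out, the change is isobutyl to benzyl, isobutoxy to benzyloxy. Among the measured compounds shown here, no measured step covers this change. The expectation is no step beyond the scatter, and compound 3 is expected to stay at the limit, a step that the limit leaves unreadable from compound 2 to compound 3. The estimate for compound 3 in this assay is 30000 nM, within 10000 nM to 100000 nM, most likely reported again as a limit.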

Compound 3, half-maximal effective concentration: > 26000 nM
Compound 3: no number, only a limit (the forecaster's own chance of this, stated with the estimate: 85%); the middle value is on the limit's open side.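

No step can be read from compound 3 to compound 1 or compound 2 in this assay, as all three compounds give a limit of the assay and not a number: the limit of > 26000 nM in this assay, at which 3 of the 3 values shown sit.

The compounds shown leave open whether isobutoxy to benzyloxy, or any other change on the shared core, shifts the half-maximal effective concentration in this assay at all.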